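The source may hold more compounds than are shown below. What is called first, only, known or untested is meant among the compounds shown, and "the series" means these compounds.

Measured compounds and their values:

compound 1, `C[C@@H](O)[C@H]1C(=O)N2C(C(=O)OCOC(=O)C(C)(C)C)=C(S[C@@H]3CN[C@H](C(=O)Nc4cccc(C(=O)O)c4)C3)[C@H](C)[C@H]12`, > 95%
compound 2, `Cc1oc(=O)oc1COC(=O)N1C[C@@H]2C[C@H]1C(=O)Nc1cccc(c1)C(=O)OC/C=C/COC(=O)C1=C(S2)[C@H](C)[C@@H]2[C@@H]([C@@H](C)O)C(=O)N12`, > 95%
compound 3, `CC(C)OC(=O)OCOC(=O)C1=C(S[C@@H]2CN[C@H](C(=O)Nc3cccc(C(=O)OCOC(=O)OC(C)C)c3)C2)[C@H](C)[C@@H]2[C@@H]([C@@H](C)O)C(=O)N12`, > 95%

In a physicochemical assay for metabolic stability, read by LC-MS, in phosphate buffer, with a stated time of 3 h, at pH 7.4, tested at 50 uM (on this read-out higher numbers stand for a more stable compound and lower numbers for a less stable compound), compound 1 gives > 95%, which is a limit of the assay rather than a number. Compound 2 gives > 95%, again a limit. Compound 3 gives > 95%, also a limit. Within the data shown here, all three measured values therefore sit at the same place, namely (the limit of > 95% in this assay, at which 3 of the 3 values shown sit), so nothing can be said about an order among compounds 1, 2 and 3, and no step between measured compounds is available from which a size could be read.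

Compound 4 `Cc1oc(=O)oc1COC(=O)N1C[C@@H]2C[C@H]1C(=O)Nc1cccc(c1)C(=O)OC/C=C\COC(=O)C1=C(S2)[C@H](C)[C@@H]2[C@@H]([C@@H](C)O)C(=O)N12` is the compound still to be measured. It differs from compound 2 as follows: the two compounds have the same atoms and bonds and differ only in configuration as drawn: 1 of 7 stereo elements differ; a double bond is drawn E in compound 2 and Z in compound 4.

Since the three values shown all rest at the limit, the account of compound 4 can lean only on where compound 2 stands. The step from compound 2 to compound 4 is expected to be none beyond the scatter, a step that the limit leaves unreadable from compound 2 to compound 4. Compound 4 is thus estimated to give 96%, with a range from 88% to 100%, and most likely again only a limit.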

Compound 4, percent of the compound remaining: > 95%
Compound 4 gave a limit, no number (the forecaster's own chance of this, stated with the estimate: 80%); the middle value is on the limit's open side.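

No step can be read from compound 2 to compound 4 in this assay, because both values are limits: the limit of > 95% in this assay, at which 4 of the 4 values shown sit.

The compounds shown leave open whether the double bond, drawn E in compound 2 and Z in compound 4, has any bearing on the stability read in this assay.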